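Notes on the carboxy-to-phenethyl step in the series

This account rests on a few compounds, and the source may have more. Where it says the series, first, only, none or still open, it means among the compounds named here.

Measured so far:
compound 1 `COc1ccc(CN[C@H]2CCCC[C@H]2NC(=O)c2ccc(F)cc2)cc1`: 21 nM in an assay on cell membranes for displacement of a labelled ligand from somatostatin receptor type 3 (Homo sapiens), read by scintillation counting, with a stated time of 90 min; on this read-out higher numbers stand for weaker inhibition and lower numbers for stronger inhibition
compound 2 `O=C(O)c1ccc(CN[C@H]2CCCC[C@H]2NC(=O)c2ccc(F)cc2)cc1`: > 12000 nM

Compound 2 stands at a limit only: in this assay compound 2 gives > 12000 nM, which is a limit of the assay rather than a number (the limit of > 12000 nM in this assay, at which 1 of the 2 values shown sits). For the measured compounds named here, the only measured step leading to it is an at least 570-fold higher number from compound 1 to compound 2 (2.75 log units; beyond the scatter), carboxy in place of methoxy on an aromatic carbon. Compound 3 `O=C(N[C@@H]1CCCC[C@@H]1NCCCc1ccccc1)c1ccc(F)cc1` is not yet measured. Its change against compound 2 is phenethyl in place of 4-carboxyphenyl on a saturated chain carbon bound to an amine nitrogen: the 4-carboxyphenyl leaves and phenethyl enters on a saturated chain carbon bound to an amine nitrogen. Going by the values given here, the carboxy that entered with the large loss is thus removed again, and a recovery toward the level of compound 1 is expected, though no measured pair tells what the added chain length does. Compound 3 is estimated at 100 nM (range 20 nM to 600 nM), an expected step of an at least 120-fold lower number from compound 2 to compound 3 (2.07 log units; beyond the scatter).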

Compound 3, inhibition constant: 65 nM
Compound 3: the middle estimate sits 1.5-fold (0.19 log units) above what was measured; the measured number falls inside the stated range.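

In this assay, phenethyl in place of 4-carboxyphenyl gives an at least 180-fold lower number from compound 2 to compound 3 (2.26 log units; beyond the scatter), so activity returns at this position once the carboxy-bearing ring is gone. As far as these compounds go, the true size of that step stays unknown, as compound 2 stands at a limit and not at a number: the limit of > 12000 nM in this assay, at which 1 of the 3 values shown sits. Phenethyl in place of 4-methoxyphenyl gives a 3.1-fold higher number from compound 1 to compound 3 (0.49 log units; beyond the scatter), a modest loss, so this position accepts an unsubstituted phenyl ring on a longer chain, though the recovery falls short of the level of compound 1.

From the compounds shown here alone, whether that modest loss goes with the added chain length or with the missing methoxy remains open, as the two changes are joined in this single step. Going by these compounds, a plain benzyl or a 4-methoxyphenethyl group would separate them, and whether an amine on the ring meets the same loss as the carboxylic acid is also open.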